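This account rests on a few compounds, and the source may have more. Where it says the series, first, only, none or still open, it means among the compounds named here.

Compound 1 `CCOC(=O)c1cnc(N2CCN(Cc3ccccc3[N+](=O)[O-])CC2)nc1Oc1c(C)cc(-c2ccc(C#N)cc2)cc1C` gives >= 78700 nM
Compound 2 `CCOC(=O)c1cnc(N2CCN(Cc3ccc(S(C)(=O)=O)cc3)CC2)nc1Oc1c(C)cc(-c2ccc(C#N)cc2)cc1C` gives > 125000 nM

In an ADME assay on MT4 cells (Homo sapiens) for cytotoxicity, read by MTT assay, with a stated time of 4 days (on this read-out higher numbers stand for lower toxicity in this test and lower numbers for higher toxicity in this test), compound 1 reaches only a limit, >= 78700 nM. Compound 2 also stands at a limit, > 125000 nM. The step that the two limits leave unreadable from compound 1 to compound 2 therefore cannot be sized. Compound 3 `CCOC(=O)c1cnc(N2CCN(Cc3cc(C)cc(C)c3)CC2)nc1Oc1c(C)cc(-c2ccc(C#N)cc2)cc1C` differs from compound 2 by 3,5-dimethylphenyl in place of 4-(methylsulfonyl)phenyl on a saturated chain carbon bound to an amine nitrogen in a ring. For the measured compounds named here, the only evidence bearing on such a change is the limit of > 125000 nM in this assay, at which 1 of the 2 values shown sits, and (the limit of >= 78700 nM in this assay, at which 1 of the 2 values shown sits), which leave the direction and size of any step unread. Compound 3 is expected to remain of low toxicity in this assay, the step of a number no higher from compound 2 to compound 3 (the limit leaves the size open) being estimated as none beyond the scatter. Compound 3 is estimated at 125000 nM, with a range from 40000 nM to 250000 nM.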

Compound 3, half-maximal cytotoxic concentration: > 125000 nM
Compound 3 gave a limit, no number (the forecaster's own chance of this, stated with the estimate: 70%); the middle value lies on the limit itself.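

For the compounds shown here, compound 1, compound 2 and compound 3 all stand at limits in this assay, and no step among them can be read. The compounds shown leave open whether exchanging these groups changes the half-maximal cytotoxic concentration at all.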